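Capping the Hydroxy Group of Compound 3

The compounds below may be only part of what the source reports. "The series", "measured", "known", "first", "only" and "open" are said of these compounds alone.

In an ADME assay on HepG2 cells (Homo sapiens) for cytotoxicity, read by MTT assay, with a stated time of 48 h (a higher number here means a weaker inhibitor, a lower number a stronger inhibitor), compound 3 `O=S(=O)(c1ccc(-c2ccc3ncnc(Nc4ccc(O)c(Cl)c4)c3c2)cc1)N1CCOCC1` gives > 15000 nM. That reading is a limit and not a number, so compound 3 has no exact place on the scale. Compound 4 `COc1cccc(COc2ccc(Nc3ncnc4ccc(-c5ccc(S(=O)(=O)N6CCOCC6)cc5)cc34)cc2Cl)c1` differs from it at one site, and the change is 3-methoxybenzyl in place of hydrogen on an oxygen on an aromatic ring. In words, hydroxy becomes (3-methoxybenzyl)oxy, while the group on the sulfonyl sulfur stays as it is.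

Among the compounds with values here, no measured step covers this change. The only one available, an at least 8.2-fold lower number from compound 1 to compound 2 (0.91 log units; beyond the scatter), is a change elsewhere, with 4-methyl-1,4-diazepan-1-yl in place of piperidin-1-yl on a sulfonyl sulfur. Within the data shown here, it ends at compound 2 `CN1CCCN(S(=O)(=O)c2ccc(-c3ccc4ncnc(Nc5ccc(OCc6cccc(F)c6)c(Cl)c5)c4c3)cc2)CC1`, which gives 1810 nM, the only true number so far. Compound 4 has no such swap, so that step does not carry over.

The closer guide is compound 1 `O=S(=O)(c1ccc(-c2ccc3ncnc(Nc4ccc(OCc5cccc(F)c5)c(Cl)c4)c3c2)cc1)N1CCCCC1`, which also has a benzyl group on that oxygen, though with fluorine instead of methoxy. Compound 1 gives > 15000 nM, which is also a limit. On that basis no step beyond the scatter is expected, and the result may well be a limit again. The estimated change is a number no higher from compound 3 to compound 4 (the limit leaves the size open). For compound 4 the expected value is 15000 nM, within an estimated range of 6000 nM to 40000 nM.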

Compound 4, half-maximal inhibitory concentration: > 15000 nM
Compound 4: only a limit was reported; the forecaster's own chance of this, stated with the estimate: 65%; the middle value sits exactly at the limit.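

In this assay compound 3 gives > 15000 nM, which is a limit. Compound 4 gives > 15000 nM, also a limit, so no step can be read between compound 3 and compound 4. Whether hydroxy to (3-methoxybenzyl)oxy changes the number at all stays open, because most readings stop at the same point: the limit of > 15000 nM in this assay, at which 3 of the 4 values shown sit.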